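Notes on a side-chain exchange in one amide series

The source may hold more compounds than are shown below. What is called first, only, known or untested is meant among the compounds shown, and "the series" means these compounds.

Measured so far:
compound 1, `COc1ccc2c(C(=S)N(C)CC(N)=O)c(F)ccc2c1C(F)(F)F`: 33%; 33% (2 entries)
compound 2, `COc1ccc2c(C(=O)N(C)CC(N)=O)c(F)ccc2c1C(F)(F)F`: 39%

In a functional assay on the whole organism (Sciatic nerve) for inhibition, with Rattus norvegicus as the target, at a dose of 5 mg/kg (a higher number here means a stronger effect of the compound at the dose given, a lower number a weaker effect), compound 1 gives 33%; 33% (2 entries) across two entries, and compound 2 gives 39%. The two values lie within the usual scatter of each other, so nothing separates compound 1 from compound 2 on these numbers. Among the compounds with values here, compound 2 stands on the only number it has in this assay; one further entry for it carries no single number.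

Compound 3 is `COC(=O)N(CC(=O)O)C(=O)c1c(F)ccc2c(C(F)(F)F)c(OC)ccc12`. It differs from compound 2 by (carboxymethyl)(methoxycarbonyl)amino in place of (carbamoylmethyl)(methyl)amino on a carbonyl carbon. No measured pair in the series spans a change of this kind, so the size of the step rests on expectation alone rather than on any shown comparison. A downward step in this assay of moderate size is expected, a number 14 percentage points lower from compound 2 to compound 3 (beyond the scatter), likely beyond the scatter but not certainly so, given how much of the side chain is exchanged. Compound 3 is estimated at 25%, with a range from 5% to 50%.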

Compound 3, a percentage reported as inhibition, in the whole organism at one dose (the size of the read-out at that dose, not a potency): 50%
Beside the measured number, compound 3's estimate is 25 percentage points below it; the measured number falls inside the stated range.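

In this assay, within the data shown here, (carboxymethyl)(methoxycarbonyl)amino in place of (carbamoylmethyl)(methyl)amino on a carbonyl carbon gives a number 11 percentage points higher from compound 2 to compound 3 (beyond the scatter) and is the first change with a step beyond the scatter, since the printed values of compound 1 and compound 2 lie within the scatter of each other. This position therefore accepts the larger entering group, with 9 heavy atoms against 6 and 2 double bonds against 1, without loss of effect at the dose given, and the read-out here responds to a change in this side chain. Nothing available accounts for the rise, and it stands as an observation only.

The exchange alters both arms of the side chain at once, so the step cannot be divided between the carboxymethyl arm and the methoxycarbonyl arm. Open questions are how (carboxymethyl)(methyl)amino, which would separate the two arms, or a longer chain such as carboxyethyl would read at this position, and whether the step seen at one dose would carry over to other doses.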